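A few compounds are considered here, and "the series" means these few. Any claim that something is new, unique, unknown or untested is made for them only; others in the source may bear on it.

Measured compounds:
Compound 1, `CN(C(=O)NC(=O)c1ccc(C(F)(F)F)cc1)c1nc(C(F)(F)F)c(C(=O)N/N=C/c2cc(C(F)(F)F)cc(C(F)(F)F)c2)s1` — 5.9 ug/mL
Compound 2, `Cc1nc(N(C)C(=O)NC(=O)c2c(F)cccc2F)sc1C(=O)N/N=C/c1cc(C(F)(F)F)cc(C(F)(F)F)c1` — 13 ug/mL

In a functional assay on A549 cells (Homo sapiens) for inhibition, read by MTT assay, with a stated time of 72 h (on this read-out higher numbers stand for weaker inhibition and lower numbers for stronger inhibition), compound 2 gives the higher of the two numbers; compound 1 gives the lower one, and the gap between them lies beyond the usual scatter. Compound 3, `CN(C(=O)NC(=O)c1c(F)cccc1F)c1nc(C(F)(F)F)c(C(=O)N/N=C/c2cc(C(F)(F)F)cc(C(F)(F)F)c2)s1`, keeps the core of compound 2 but differs in one place: trifluoromethyl in place of methyl on an aromatic carbon. Among the compounds with values here, no pair of measured compounds isolates this change, so its effect in this assay is not known from the numbers here. Compound 3 is expected to give a value somewhat below that of compound 2, a step of a 1.4-fold lower number from compound 2 to compound 3 (0.16 log units; within the scatter) that stays close to the scatter. The estimate for compound 3 is 9 ug/mL, within 4 ug/mL to 20 ug/mL.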

Compound 3, half-maximal inhibitory concentration: 17.3 ug/mL
For compound 3 the middle estimate is 1.9-fold (0.28 log units) below the measured one; the range from low to high includes it.
By their numbers in this assay, from the lowest: compound 1; then compounds 2 and 3 (each within the scatter of the next).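

In this assay trifluoromethyl in place of methyl on an aromatic carbon, next to the ring nitrogen, gives a 1.3-fold higher number from compound 2 to compound 3 (0.12 log units; within the scatter) and so leaves the two compounds indistinguishable. With trifluoromethyl held at that position, 2,6-difluorophenyl in place of 4-(trifluoromethyl)phenyl on a carbonyl carbon gives a 2.9-fold higher number from compound 1 to compound 3 (0.47 log units; beyond the scatter) and is the only single change shown that exceeds the scatter. Nothing available bears on the reason for either step. From the compounds shown here alone, whether an amine or a chlorine atom on that aromatic carbon would read like methyl and trifluoromethyl remains open. So does whether 4-(trifluoromethyl)phenyl would give the same step with methyl on the ring.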